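Adding a Methoxycarbonyl Group to an Inactive Scaffold

The compounds below may be only part of what the source reports. "The series", "measured", "known", "first", "only" and "open" are said of these compounds alone.

Compound 1, `CCCn1c(NC(=O)c2cc(C)nn2CC)nc2cc(C(N)=O)ccc21`, gives > 100000 nM in an assay for activation of interferon regulatory factor 3 (Homo sapiens), read by a luciferase reporter, with a stated time of 20 h; a lower number here means that less compound is needed, a higher number that more compound is needed for the effect. Compound 2, `CCCn1c(NC(=O)c2cc(C)nn2CC)nc2cccc(OC)c21`, gives > 100000 nM in this assay.

Each of these values is a limit of the assay, not a number. Compound 2 therefore stands at the limit of > 100000 nM in this assay, at which 2 of the 2 values shown sit, and nothing separates it from compound 1. Compound 3, `CCCn1c(NC(=O)c2cc(C)nn2CC)nc2cc(C(=O)OC)cc(OC)c21`, differs from compound 2 by methoxycarbonyl in place of hydrogen on an aromatic carbon. Within the data shown here, no step between measured compounds is available to gauge this change, so any expectation rests on the shared limit alone. Compound 3 is expected to stay close to that limit, with a step of an at least 1.2-fold lower number from compound 2 to compound 3 (0.09 log units; that floor lies within the scatter) at most. The estimated value of compound 3 is 80000 nM, within a range from 20000 nM to 200000 nM.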

Compound 3, half-maximal effective concentration: > 100000 nM
Compound 3: only a limit was reported; the forecaster's own chance of this, stated with the estimate: 75%; at least 1.2-fold (0.09 log units) between middle value and limit.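

Among these compounds, compound 2 and compound 3 both give only a limit in this assay, so no step between them can be read. The compounds shown leave open whether methoxycarbonyl in place of hydrogen on an aromatic carbon changes the effect at all.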